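This account rests on a few compounds, and the source may have more. Where it says the series, first, only, none or still open, it means among the compounds named here.

In a functional assay on MGC-803 cells (Homo sapiens) for inhibition, read by MTT assay, with a stated time of 72 h (on this read-out higher numbers stand for weaker inhibition and lower numbers for stronger inhibition), compound 1 (`O=C(Nc1ccccc1)C1CCN(C/C=C/c2ccccc2)CC1`) gives 57900 nM and compound 2 (`O=C(Nc1cccc(Br)c1)C1CCN(C/C=C/c2ccccc2)CC1`) gives 9110 nM as the lower of the two numbers. Compound 3 (`O=C(Nc1ccc(F)c(Br)c1)C1CCN(C/C=C/c2ccccc2)CC1`) differs from compound 2 by one change (fluoro in place of hydrogen on an aromatic carbon), fluoro in place of hydrogen on an aromatic carbon. Among the compounds with values here, the one measured step that bears on this, bromo in place of hydrogen on an aromatic carbon (a 6.4-fold lower number from compound 1 to compound 2 (0.80 log units; beyond the scatter)), is modest and beyond the scatter, so a smaller step toward a lower number is expected in this assay. The estimated step (a 1.5-fold lower number from compound 2 to compound 3 (0.18 log units; within the scatter)) may stay within the scatter. For compound 3 the expected value is 6000 nM within an estimated range from 2200 nM to 16000 nM as a guide.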

Compound 3, half-maximal inhibitory concentration: 9270 nM
The estimate for compound 3 lay 1.5-fold (0.19 log units) below the measured number, within the range that was stated.
By their numbers in this assay, from the lowest: compounds 2 and 3 (each within the scatter of the next); then compound 1.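

In this assay, fluoro on the aromatic carbon ortho to a bromo group brings no change that can be told from the scatter, with a 1.0-fold higher number from compound 2 to compound 3 (0.01 log units; within the scatter). The advantage over the unsubstituted phenyl therefore remains in the 3-bromo-4-fluorophenyl compound, with a 6.2-fold lower number from compound 1 to compound 3 (0.80 log units; beyond the scatter). No available evidence explains why this fluoro leaves the number unmoved.

From the compounds shown here alone, whether a different group at this position, such as methoxy or an amine, would shift the number remains open. So does whether fluoro would matter on a ring without the bromo group.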